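Adding a Third Methoxy Group to Compound 2

A few compounds are considered here, and "the series" means these few. Any claim that something is new, unique, unknown or untested is made for them only; others in the source may bear on it.

Compound 1, `COc1cc(-c2cc(/C=C/C(=O)c3ccc(Cl)c(Cl)c3)[nH]n2)cc(OC)c1OC`: -65%
Compound 2, `COc1ccc(-c2cc(/C=C/C(=O)c3cc(OC)c(OC)c(OC)c3)[nH]n2)cc1OC`: -90%

Within the data shown here, in a functional assay on NCI-H522 cells (Homo sapiens) for cytotoxicity, read by sulforhodamine B assay, with a stated time of 48 h, tested at 100 uM (on this read-out lower numbers stand for a stronger effect and higher numbers for a weaker effect at the one concentration tested), compound 2 gives -90%, the lowest of the two numbers measured so far. Its nearest neighbour, compound 1, gives -65%, and the gap between the two lies beyond the usual scatter, so compound 2 stands as the stronger of the pair on this read-out.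

Compound 3, `COc1cc(C(=O)/C=C/c2cc(-c3cc(OC)c(OC)c(OC)c3)n[nH]2)cc(OC)c1OC`, has not yet been measured. It differs from compound 2 in one place: methoxy in place of hydrogen on an aromatic carbon. Among the measured compounds shown here, no step between measured compounds carries this particular change, so the data give no direct size for it. The expected step is a number 5 percentage points higher from compound 2 to compound 3 (within the scatter), a shift that would stay within the scatter of repeated measurements. Compound 3 is accordingly estimated at -85%, with a range from -100% to -60%.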

Compound 3, a percentage reported as activity, at one concentration (the size of the read-out at that concentration, not a potency): -98%
The estimate for compound 3 lay 13 percentage points above the measured number; low and high end bracket the measured number.
By their numbers in this assay, from the lowest: compounds 3 and 2 (each within the scatter of the next); then compound 1.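

The added methoxy, on an aromatic carbon ortho to a methoxy group and meta to a large group, gives a step in this assay of a number 8 percentage points lower from compound 2 to compound 3 (within the scatter). Among these compounds, this is the first step that can be read at one place, and it shows that hydrogen and methoxy at this position cannot be told apart on this read-out. Nothing measured here offers a reason for this result.

Going by these compounds, what a hydroxyl group, an amine or a longer chain such as ethoxy would do at this position remains open. Because the read-out comes from a single concentration, it also leaves open whether compound 2 and compound 3 differ in potency.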